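The compounds below may be only part of what the source reports. "The series", "measured", "known", "first", "only" and "open" are said of these compounds alone.

Measured in an assay on isolated protein for activation of Nicotinamide phosphoribosyltransferase (Homo sapiens); on this read-out lower numbers stand for an effect already at smaller amounts and higher numbers for an effect only at larger amounts of compound:
compound 1 `CN(Cc1ccccc1)S(=O)(=O)c1ccc(NC(=O)NCc2ccncc2)cc1` gives 23 nM
compound 2 `CCOC(=O)c1ccc(NC(=O)NCc2c[nH]nn2)cc1` gives 7750 nM
compound 3 `CCOC(=O)c1ccc(NC(=S)NCc2ccncc2)cc1` gives 9770 nM

Compound 2 stands at the high end of these three numbers, close to compound 3, the gap between the two lying within the scatter; the gap to compound 1 is large and beyond it. Within the data shown here, no single-point step between measured compounds is available: compound 2 and compound 3 differ in two places at once, and compound 1 differs from both in more than one place. Compound 4 `CCOC(=O)c1ccc(NC(=O)NCc2ccncn2)cc1` is made from compound 2 by the change (pyrimidin-4-yl in place of 1H-1,2,3-triazol-4-yl on a saturated chain carbon bound to an amide-type nitrogen). Among the measured compounds shown here, the only guidance is indirect: compound 1, which also carries a six-membered aromatic ring on the saturated chain carbon bound to the amide-type nitrogen, sits far lower than compound 2, while compound 3, which carries such a ring together with the ester, sits next to compound 2. The swap to a six-membered ring is therefore expected to give a modest downward step in this assay, possibly within the scatter, from compound 2 to compound 4 a 2.2-fold lower number from compound 2 to compound 4 (0.35 log units; beyond the scatter). Compound 4 is expected to give 3500 nM, in the range 900 nM to 14000 nM.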

Compound 4, half-maximal effective concentration: 13600 nM
Beside the measured number, compound 4's estimate is 3.9-fold (0.59 log units) below it; the range from low to high includes it.
By their numbers in this assay, from the lowest: compound 1; then compounds 2, 3 and 4 (each within the scatter of the next).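

In this assay, among these compounds, the one single-place step reads a 1.8-fold higher number from compound 2 to compound 4 (0.24 log units; within the scatter), with pyrimidin-4-yl in place of 1H-1,2,3-triazol-4-yl on a saturated chain carbon bound to an amide-type nitrogen. On the core shared by compound 2 and compound 4, exchanging a five-membered aromatic ring that has a hydrogen-bond donor for a six-membered aromatic ring that has none therefore gives no difference beyond the scatter. Nothing at hand bears on the reason for this result.

On these data alone, whether the same exchange gives a similar result on the core of compound 1 remains open. Also open, as far as these compounds go, is how this position responds to a group without an aromatic ring, such as a primary amine or a carboxylic acid on the chain.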